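The compounds below may be only part of what the source reports. "The series", "measured", "known", "first", "only" and "open" are said of these compounds alone.

Of the compounds shown here, three of one shared core have been measured so far. Compound 1 `CCCCNc1nc(N)nc(C)c1CCCn1c(C)nc2ccccc21` gives 366 nM in an assay on HEK293 cells for agonist activity at Toll-like receptor 8 (Homo sapiens), read by spectrophotometry; a higher number here means that more compound is needed for the effect, a lower number that less compound is needed. Compound 2 `CCCCNc1nc(N)nc(C)c1CCCN1C(=O)c2ccccc2C1=O` gives 453 nM in this assay, and compound 3 `CCCCNc1nc(N)nc(C)c1CCCC` gives 780 nM. Compound 3 therefore stands with the highest of the three numbers: against compound 2 the gap lies within the scatter, while compound 1 needs clearly less compound than compound 3.

The next compound, compound 4 `CCCCNc1nc(N)nc(C)c1CCCN(CC)CC`, is not yet measured. It differs from compound 3 in one place: diethylamino in place of methyl on a saturated chain carbon, three bonds along the chain from an aromatic carbon. Compounds 1 and 2 both carry a larger group at the end of that chain than compound 3 and both return lower numbers, so a modest drop in the number is expected for compound 4, no larger than about the scatter, with the step from compound 3 to compound 4 estimated at a 1.7-fold lower number from compound 3 to compound 4 (0.24 log units; within the scatter). Compound 4 is thus expected to give around 450 nM in this assay, estimated within a range from 150 nM to 1300 nM.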

Compound 4, half-maximal effective concentration: 254 nM
Estimate against measurement, compound 4: 1.8-fold (0.25 log units) above; the measured number falls inside the stated range.
By their numbers in this assay, from the lowest: compounds 4, 1, 2 and 3 (each within the scatter of the next, the first and the last beyond it).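

Diethylamino in place of methyl on a saturated chain carbon, three bonds along the chain from an aromatic carbon, gives a 3.1-fold lower number from compound 3 to compound 4 (0.49 log units; beyond the scatter) in this assay. Among the compounds shown here, this is the first change in one place that can be read at this position, and it shows that the larger group carrying a nitrogen is accepted there with a real drop in the number, not merely a shift within the scatter. Nothing measured here explains this drop.

The compounds shown leave open whether the drop goes with the nitrogen or with the added carbons, a question that dimethylamino, a piperidine or a plain longer alkyl chain at this place would address. On these data alone, it also remains open how the number responds when diethylamino sits on a shorter or a longer chain.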